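From compound 1 to compound 3: a longer chain

The source may report more compounds than this note shows. Statements on the series, on what has been measured and on what is new or still open speak of the compounds shown alone.

Of the compounds shown here, two have numbers so far. In a functional assay on HepG2 cells (Homo sapiens) for cytotoxicity (on this read-out higher numbers stand for weaker inhibition and lower numbers for stronger inhibition), compound 1 (`CCCO[C@H]1C=C(COC(C)=O)C(=O)[C@H](O)[C@H]1O`) gives 33600 nM as the higher of the two numbers, so it stands at the weak end of this small set. Compound 2 (`CCCCCO[C@@H]1C=C(COC(C)=O)C(=O)[C@H](O)[C@H]1O`) gives 10100 nM as the nearest and only other number, lower by a margin beyond the scatter.

Compound 3 (`CCCCCCCO[C@H]1C=C(COC(C)=O)C(=O)[C@H](O)[C@H]1O`) has not been measured. It differs from compound 1 by butyl in place of hydrogen on a saturated chain carbon, three bonds along the chain from an oxygen on a saturated carbon in one place: butyl in place of hydrogen on a saturated chain carbon, three bonds along the chain from an oxygen on a saturated carbon. The same difference reads as propyl to heptyl.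

Within the data shown here, the only guide is compound 2 at 10100 nM with its pentyl chain, and two numbers do not establish a trend. A move to a lower number in this assay is expected, beyond the scatter but uncertain in size. The expected step is a 5.6-fold lower number from compound 1 to compound 3 (0.75 log units; beyond the scatter) toward stronger inhibition. For compound 3 the estimated value is 6000 nM with an expected range from 1800 nM to 20000 nM in this read-out.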

Compound 3, half-maximal inhibitory concentration: > 50000 nM
Compound 3 was reported as a limit; the forecaster's own chance of this, stated with the estimate: 5%; at least 8.3-fold (0.92 log units) between middle value and limit.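

In this assay, compound 3 is reported as a limit, > 50000 nM. With propyl to heptyl at this position, butyl in place of hydrogen on a saturated chain carbon, three bonds along the chain from an oxygen on a saturated carbon, gives an at least 1.4-fold higher number from compound 1 to compound 3 (0.17 log units; that floor lies within the scatter), so this one-place change offers no sign of stronger inhibition, and the floor of the step alone does not establish a real loss. The earlier compounds gave no reading of a single change at this position, and this first reading has a floor but no measured size: the limit of > 50000 nM in this assay, at which 1 of the 3 values shown sits.

From the compounds shown here alone, whether a nonyl chain, or a heptyl chain ending in an amine or a carboxylic acid, would give a number within the range of this assay remains open. Compound 2 is joined to neither compound 1 nor compound 3 by a step in one place, so the effect of its pentyl chain cannot be read from the compounds shown.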